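Swapping Methyl for Trifluoromethyl on the Aromatic Oxygen

The source may hold more compounds than are shown below. What is called first, only, known or untested is meant among the compounds shown, and "the series" means these compounds.

Compound 1, `COC(=O)C1=C(C)N=C(C)/C(=C(/O)OC)C1c1cccc(NC(=O)NCCNC2CCN(c3ccccc3C(F)(F)F)CC2)c1`: 31 nM
Compound 2, `COC(=O)C1=C(C)N=C(C)/C(=C(/O)OC)C1c1cccc(NC(=O)NCCNC2CCN(c3ccccc3OC)CC2)c1`: 2 nM

In an assay on SK-N-MC cells for inhibition of Neuropeptide Y receptor type 1 (Homo sapiens) (a lower number here means a stronger inhibitor, a higher number a weaker inhibitor), compound 2 stands lowest of the two numbers shown, with compound 1 as its only neighbour. Among the compounds with values here, the one measured step, a 16-fold lower number from compound 1 to compound 2 (1.19 log units; beyond the scatter), is large and beyond the scatter. Compound 3, `COC(=O)C1=C(C)N=C(C)/C(=C(/O)OC)C1c1cccc(NC(=O)NCCNC2CCN(c3ccccc3OC(F)(F)F)CC2)c1`, differs from compound 2 by trifluoromethyl in place of methyl on an oxygen on an aromatic ring. Within the data shown here, no measured step covers this exact change, but it moves the structure part of the way toward compound 1, so a step of a 4.0-fold higher number from compound 2 to compound 3 (0.60 log units; beyond the scatter) is expected, toward a higher number. Compound 3 is therefore estimated at 8 nM, with a range from 2 nM to 40 nM.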

Compound 3, half-maximal inhibitory concentration: 25 nM
For compound 3 the middle estimate is 3.1-fold (0.49 log units) below the measured one; measured number inside the range.
By their numbers in this assay, from the lowest: compound 2; then compounds 3 and 1 (each within the scatter of the next).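

In this assay, replacing methyl with trifluoromethyl on this oxygen brings a 13-fold higher number from compound 2 to compound 3 (1.10 log units; beyond the scatter) and removes the advantage that methoxy showed. The oxygen alone therefore does not preserve that advantage: a 1.2-fold lower number from compound 1 to compound 3 (0.09 log units; within the scatter) leaves trifluoromethoxy and trifluoromethyl indistinguishable on this aromatic carbon. Nothing available explains this result.

The compounds shown leave open how ethoxy, hydroxyl or chlorine would compare at the same place. They also leave open whether methoxy would keep its advantage with a different chain on the shared core.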